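This account rests on a few compounds, and the source may have more. Where it says the series, first, only, none or still open, it means among the compounds named here.

Compound 1 `COc1cc(C(=O)c2cn(-c3ccccc3)cc2-c2cccc(N)c2)cc(OC)c1OC`: 28 nM
Compound 2 `COc1cc(C(=O)c2cn(-c3ccccc3)cc2-c2ccc(F)cc2)cc(OC)c1OC`: 78 nM

These values come from a functional assay on MCF7 cells (Homo sapiens) for inhibition, read by trypan blue exclusion, with a stated time of 3 days; on this read-out higher numbers stand for weaker inhibition and lower numbers for stronger inhibition. Of the two, compound 2 has the higher number, 78 nM, so it is the weaker inhibitor so far. Compound 3 `COc1cc(C(=O)c2cn(-c3ccccc3)cc2-c2ccc(N)cc2)cc(OC)c1OC` differs from it in one place, with amino in place of fluoro on an aromatic carbon, para to a large group (amino in place of fluoro on an aromatic carbon). Going by the values given here, one measured step bears on this change: a 2.8-fold higher number from compound 1 to compound 2 (0.44 log units; beyond the scatter). It replaces 3-aminophenyl with 4-fluorophenyl, and it is modest but beyond the scatter. Compound 1 carries 3-aminophenyl rather than the 4-aminophenyl of compound 3, so this step is only a loose guide. A step of similar size in the opposite direction, towards a lower number in this assay, is expected. The estimated change is a 2.6-fold lower number from compound 2 to compound 3 (0.41 log units; beyond the scatter). For compound 3 the estimated value is 30 nM, with an expected range of 10 nM to 90 nM.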

Compound 3, half-maximal inhibitory concentration: 9 nM
Beside the measured number, compound 3's estimate is 3.3-fold (0.52 log units) above it; measured number outside the range, below it.
By their numbers in this assay, from the lowest: compound 3; then compound 1; then compound 2.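

In this assay, the earlier step changed both the group and its place at once, whereas these two steps separate them. With the place held, amino in place of fluoro, para to a large group, gives an 8.7-fold lower number from compound 2 to compound 3 (0.94 log units; beyond the scatter), so the identity of the group at this position matters. With amino kept, 4-aminophenyl in place of 3-aminophenyl gives a 3.1-fold lower number from compound 1 to compound 3 (0.49 log units; beyond the scatter), so where the amino sits matters too, though nothing shown gives a cause for either step.

Still open, as far as these compounds go, is whether a hydroxyl or a methylamino group at this same place would match the number for compound 3 or fall back towards that of compound 2. A 3-fluorophenyl group is not among these compounds, so it also remains open whether fluoro responds to the same shift of place as amino.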